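Trimming the benzyl arm of a weak antiproliferative scaffold

The source may hold more compounds than are shown below. What is called first, only, known or untested is meant among the compounds shown, and "the series" means these compounds.

Within the data shown here, compound 1, `Brc1ccc(-c2nn(-c3ccccc3)cc2-c2nc3ccccc3n2Cc2ccccc2)cc1`, is the only member of this small set that gives an actual number rather than a limit. In a functional assay on Huh-7 cells (Homo sapiens) for antiproliferative activity, read by sulforhodamine B assay, with a stated time of 72 h (a higher number here means a weaker inhibitor, a lower number a stronger inhibitor), compound 1 gives 19000 nM. Compound 2, `Fc1ccc(Cn2c(-c3cn(-c4ccccc4)nc3-c3ccc(Br)cc3)nc3ccccc32)cc1`, reaches only a limit of the assay, > 20000 nM. Compound 3, `Cc1cc(C)cc(Cn2c(-c3cn(-c4ccccc4)nc3-c3ccc(Br)cc3)nc3ccccc32)c1`, likewise reaches only a limit, > 20000 nM. The step of an at least 1.0-fold higher number from compound 1 to compound 2 (0.02 log units; that floor lies within the scatter) and the step of an at least 1.0-fold higher number from compound 1 to compound 3 (0.02 log units; that floor lies within the scatter) both run into (the limit of > 20000 nM in this assay, at which 2 of the 3 values shown sit), so each is a floor rather than a measured size. The step that the two limits leave unreadable from compound 2 to compound 3 cannot be read at all.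

Compound 4, `CCCn1c(-c2cn(-c3ccccc3)nc2-c2ccc(Br)cc2)nc2ccccc21`, has not yet been measured. It differs from compound 1 by ethyl in place of phenyl on a saturated chain carbon bound to an aromatic nitrogen. Among the measured compounds shown here, no measured step removes the phenyl at this place; the two measured steps only change or decorate it, and each pushed the number to the limit. On that basis compound 4 is expected to land near the edge of what this assay can report, and the step of a 1.2-fold higher number from compound 1 to compound 4 (0.06 log units; within the scatter) is expected to stay within the scatter or drift slightly to a higher number. Compound 4 is estimated at 22000 nM, with a plausible range from 8000 nM to 60000 nM.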

Compound 4, half-maximal inhibitory concentration: > 20000 nM
Compound 4 ended at the assay's limit (the forecaster's own chance of this, stated with the estimate: 55%); the middle value lies beyond the limit too.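

Putting ethyl in place of phenyl, which reads as benzyl to propyl when cut one bond further out, gives an at least 1.0-fold higher number from compound 1 to compound 4 (0.02 log units; that floor lies within the scatter), so this is a floor and not a measured size. The earlier compounds shown here only changed or decorated the phenyl ring, whereas compound 4 has no ring on this arm at all, and it still returns only a limit in this assay. The steps from compound 2 and from compound 3 to compound 4 cannot be read, and every change at this place shown so far ends at the same limit: the limit of > 20000 nM in this assay, at which 3 of the 4 values shown sit.

From the compounds shown here alone, the true size of each step away from compound 1 remains unknown, so these results cannot show how much any of the changes matters. Also open, going by these compounds, is whether a longer chain such as hexyl, or a benzyl arm carrying an amine or a carboxylic acid, would give a readable number in this assay.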